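The source may hold more compounds than are shown below. What is called first, only, known or untested is meant among the compounds shown, and "the series" means these compounds.

Compound 1 `NC(=O)c1ccccc1-c1cc(Nc2ccc(OC(F)(F)F)cc2)ncn1`: in an ADME assay on BaF3 cells (Mus musculus) for cytotoxicity (a higher number here means that more compound is needed for the effect, a lower number that less compound is needed), compound 1 gives > 10000 nM, which is a limit of the assay.
Compound 2 `Cc1c(-c2cc(Nc3ccc(OC(F)(F)F)cc3)ncn2)cnn1-c1ccccc1`: in this assay compound 2 gives > 10000 nM, again a limit.
Compound 3 `FC(F)(F)Oc1ccc(Nc2ncnc3c2cnn3C2CCCCC2)cc1`: in this assay compound 3 gives 9300 nM.

Compound 1 thus stands only at a limit in this assay, and it shares that position with compound 2, as the limit of > 10000 nM in this assay, at which 2 of the 3 values shown sit. Compound 3 reports a number close to that limit. For the measured compounds named here, no single-point step between measured compounds is available here.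

Compound 4 `NC(=O)c1ccc(-c2cc(Nc3ccc(OC(F)(F)F)cc3)ncn2)cc1` differs from compound 1 by 4-carbamoylphenyl in place of 2-carbamoylphenyl on an aromatic carbon. Going by the values given here, with no measured step to rest on, the change is expected to leave the half-maximal effective concentration near the limit, so a number no higher from compound 1 to compound 4 (the limit leaves the size open) is expected to be none beyond the scatter. Compound 4 is therefore expected to give 10000 nM, between 5000 nM and 30000 nM.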

Compound 4, half-maximal effective concentration: > 10000 nM
Compound 4: only a limit was reported (the forecaster's own chance of this, stated with the estimate: 70%); the middle value sits exactly at the limit.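

Compound 1 and compound 4 both report only a limit in this assay, and the step between them cannot be read. The compounds shown leave open whether 4-carbamoylphenyl in place of 2-carbamoylphenyl changes the half-maximal effective concentration at all.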